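A few compounds are considered here, and "the series" means these few. Any claim that something is new, unique, unknown or untested is made for them only; others in the source may bear on it.

Compound 1 `O=C(OC1CCC(CN2CCN(c3cc(=O)c4cc(C(F)(F)F)cc([N+](=O)[O-])c4s3)CC2)CC1)C1CCCCC1` is the starting point here. In an ADME assay on cells (Hepatocyte, Homo sapiens) for metabolic stability (on this read-out lower numbers stand for a shorter-lived compound and higher numbers for a longer-lived compound), compound 1 gives 0.0967 h, the higher of the two plain numbers in the set, with compound 2 as its nearest neighbour. Compound 2 `O=C(OC1CCC(CN2CCN(c3cc(=O)c4cc(C(F)(F)F)cc([N+](=O)[O-])c4s3)CC2)CC1)c1ccco1` gives 0.075 h in this assay, and the step of a 1.3-fold lower number from compound 1 to compound 2 (0.11 log units; within the scatter) shows that swapping the group on the carbonyl carbon for another ring changed little. Compound 3 `CC(=O)NC1CCC(CN2CCN(c3cc(=O)c4cc(C(F)(F)F)cc([N+](=O)[O-])c4s3)CC2)CC1` is different in kind: its result in this assay is a limit, > 1.55 h, rather than a number. The step of an at least 16-fold higher number from compound 1 to compound 3 (1.20 log units; beyond the scatter) is large, and it comes with the acetamido group replacing the whole (cyclohexylcarbonyl)oxy group, not with a change on the carbonyl carbon alone; here the limit of > 1.55 h in this assay, at which 1 of the 3 values shown sits, sets the ceiling of what can be said.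

Among the compounds with values here, compound 4 `O=C(OC1CCC(CN2CCN(c3cc(=O)c4cc(C(F)(F)F)cc([N+](=O)[O-])c4s3)CC2)CC1)c1ccncc1` has not been measured. pyridin-4-yl in place of cyclohexyl on a carbonyl carbon This is the same kind of change as the one from compound 1 to compound 2, where the (cyclohexylcarbonyl)oxy group stays and only the ring on its carbonyl carbon is exchanged. That step stayed within the scatter, so the expected step from compound 1 to compound 4 in this assay is a 1.0-fold higher number from compound 1 to compound 4 (0.01 log units; within the scatter). Compound 4 is therefore estimated at 0.1 h, with a range from 0.04 h to 0.3 h.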

Compound 4, half-life: 0.075 h
For compound 4 the middle estimate is 1.3-fold (0.12 log units) above the measured one; the measured number falls inside the stated range.
By their numbers in this assay, from the lowest: compounds 2, 4 and 1 (each within the scatter of the next). At a limit, above all of these: compound 3.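

In this assay, the pyridin-4-yl ring on the carbonyl carbon brings a ring nitrogen and a hydrogen-bond acceptor that cyclohexyl lacks, yet the result is a 1.3-fold lower number from compound 1 to compound 4 (0.11 log units; within the scatter), and against furan-2-yl it is no change at the digits printed from compound 2 to compound 4 (within the scatter). Cyclohexyl, furan-2-yl and pyridin-4-yl thus lie within the scatter of one another across compounds 1, 2 and 4, a saturated ring and two different aromatic rings alike, while replacing the whole group on the saturated ring carbon still gives a large step: an at least 20-fold lower number from compound 3 to compound 4 (1.31 log units; beyond the scatter). Compound 3 is known only through a limit, so the full size of that last step stays undefined: the limit of > 1.55 h in this assay, at which 1 of the 4 values shown sits.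

Still open, going by these compounds, is which part of the acetamido group goes with the large step, the nitrogen link on the saturated ring carbon or the small acetyl group on it, and a cyclohexylcarbonyl or pyridin-4-ylcarbonyl group joined through an amide nitrogen would separate the two. Also open, on these data alone, is whether a group of another kind on the carbonyl carbon, such as an open alkyl chain or an amine, would stay within the scatter of these three rings.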